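Three Inactive Compounds and One Still Untested

The source may report more compounds than this note shows. Statements on the series, on what has been measured and on what is new or still open speak of the compounds shown alone.

Measured in a functional assay on MCF7 cells (Homo sapiens) for antiproliferative activity, read by MTT assay, with a stated time of 72 h; on this read-out lower numbers stand for stronger inhibition and higher numbers for weaker inhibition:
- Compound 1 `CC1=CC[C@H]2[C@@H]1CC=C(C)[C@@H](CC[C@H]1[C@]3(C)CC[C@H](OC(=O)CCC(=O)O)C(C)(C)O[C@H]3CC[C@@]1(C)O)C2(C)C`: > 50000 nM
- Compound 2 `CC1=CC[C@H]2[C@H](CC[C@]2(C)O)C(C)(C)[C@@H]1CC[C@H]1[C@]2(C)CC[C@H](OCc3ccccc3)C(C)(C)O[C@H]2CC[C@@]1(C)O`: > 50000 nM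
- Compound 3 `CC1=CC[C@H]2[C@H](CC[C@]2(C)O)C(C)(C)[C@@H]1CC[C@H]1[C@]2(C)CC[C@H](OC(=O)NS(=O)(=O)c3ccc(C)cc3)C(C)(C)O[C@H]2CC[C@@]1(C)O`: > 50000 nM

Compound 3 stands at > 50000 nM, which is a limit and not a number. The other two results are limits as well, so the series offers no exact value yet: the limit of > 50000 nM in this assay, at which 3 of the 3 values shown sit.

Compound 4 `CC1=CC[C@H]2[C@H](CC[C@]2(C)O)C(C)(C)[C@@H]1CC[C@H]1[C@]2(C)CC[C@H](OC(=O)c3cccc([N+](=O)[O-])c3)C(C)(C)O[C@H]2CC[C@@]1(C)O` keeps the core of compound 3 and differs on a carbonyl carbon, where 3-nitrophenyl replaces ((4-methylphenyl)sulfonyl)amino: 3-nitrophenyl in place of ((4-methylphenyl)sulfonyl)amino on a carbonyl carbon. Among the compounds with values here, no measured pair shows what such a swap does, and limits cannot give the true size of a step.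

In this assay I expect no change beyond the scatter, in either direction, and this expectation rests only on the shared result of compound 1, compound 2 and compound 3: the limit of > 50000 nM in this assay, at which 3 of the 3 values shown sit. The estimated step is an at least 1.2-fold lower number from compound 3 to compound 4 (0.09 log units; that floor lies within the scatter). For compound 4 the estimated value is 40000 nM, with an expected range from 15000 nM to 80000 nM.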

Compound 4, half-maximal inhibitory concentration: 36000 nM
For compound 4 the middle estimate is 1.1-fold (0.05 log units) above the measured one, within the range that was stated.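

In this assay, within the data shown here, compound 4 gives 36000 nM, the first exact number, so a group on this carbonyl carbon can bring the result inside the measurable range. Putting 3-nitrophenyl in place of ((4-methylphenyl)sulfonyl)amino gives an at least 1.3-fold lower number from compound 3 to compound 4 (0.14 log units; that floor lies within the scatter), while putting (3-nitrophenyl)carbonyl in place of benzyl gives an at least 1.3-fold lower number from compound 2 to compound 4 (0.14 log units; that floor lies within the scatter). Going by these compounds, both steps start from limits, so each gives only a floor and the true size of the change remains unknown.

The compounds shown do not tell whether the nitro group matters, and a plain phenyl or a 3-aminophenyl on the same carbonyl carbon would test that directly. Most of the series still offers no exact value to compare with: the limit of > 50000 nM in this assay, at which 3 of the 4 values shown sit.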